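Ortho-substituent series: bromo to iodo step

The source may hold more compounds than are shown below. What is called first, only, known or untested is meant among the compounds shown, and "the series" means these compounds.

Three compounds share one core. Compound 1 `C[C@@H](NC(=O)Nc1ccccc1C(C)(C)C)c1ccccc1` gives 17% in an ADME assay on the whole organism with Oryza sativa as the target, tested at 10 uM; a higher number here means a weaker effect of the compound at the concentration tested, a lower number a stronger effect. Compound 2 `CC(=O)c1ccccc1NC(=O)N[C@H](C)c1ccccc1` gives 89%, and compound 3 `C[C@@H](NC(=O)Nc1ccccc1Br)c1ccccc1` gives 94%. Compound 3 stands at the highest of the three numbers, though compound 2 lies within the scatter of it; the change was a number 5 percentage points higher from compound 2 to compound 3 (within the scatter), whereas a number 77 percentage points higher from compound 1 to compound 3 (beyond the scatter) and a number 72 percentage points higher from compound 1 to compound 2 (beyond the scatter) were large.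

Compound 4 `C[C@@H](NC(=O)Nc1ccccc1I)c1ccccc1` differs from compound 3 in one place: iodo in place of bromo on an aromatic carbon. Going by the values given here, no measured step exchanges one halogen for another, so the nearest bearing is a number 5 percentage points higher from compound 2 to compound 3 (within the scatter), a small step between two groups at this same place, both far above compound 1. With compound 3 already near the top of the range of this assay, little room remains for a higher number, and nothing in the series points to a fall. The expected step is a number 2 percentage points lower from compound 3 to compound 4 (within the scatter), within the scatter. Compound 4 is estimated at 92%, with a range from 80% to 100%.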

Compound 4, a percentage reported as activity, at one concentration (the size of the read-out at that concentration, not a potency): 96%
For compound 4 the middle estimate is 4 percentage points below the measured one; the range from low to high includes it.
By their numbers in this assay, from the lowest: compound 1; then compounds 2, 3 and 4 (each within the scatter of the next).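

Going by these compounds alone, the first exchange of one halogen for another at this place, on an aromatic carbon ortho to a large group, gives a number 2 percentage points higher from compound 3 to compound 4 (within the scatter) in this assay, so moving from bromo to iodo leaves the read-out unchanged within the scatter. Iodo also matches acetyl, with a number 7 percentage points higher from compound 2 to compound 4 (within the scatter), whereas tert-butyl remains apart, with a number 79 percentage points higher from compound 1 to compound 4 (beyond the scatter); among these four compounds, only tert-butyl gives a separate result. No accompanying evidence bears on why these groups fall as they do.

The compounds shown leave open whether isopropyl, an amine or a carboxylic acid at this place would give a number close to that of compound 1 or close to those of compounds 2, 3 and 4. They also leave open whether the tert-butyl result holds when another part of the shared core changes.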